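A Methoxy Added to the Phenyl Ring of Compound 3

The source may hold more compounds than are shown below. What is called first, only, known or untested is meant among the compounds shown, and "the series" means these compounds.

Of the compounds shown here, three sharing one core have been measured in a functional assay on the whole organism with Rattus norvegicus as the target, at a dose of 3 mg/kg by the oral route; a higher number here means a stronger effect of the compound at the dose given, a lower number a weaker effect. Compound 1 `COc1ccc(-c2cc(Cl)cc(C(=O)Nc3nn[nH]n3)n2)cc1` gives 100% in this assay. Compound 2 `COc1ccc(-c2cc(OC)cc(C(=O)Nc3nn[nH]n3)n2)cc1` gives 60% in this assay. Compound 3 `Cc1cc(C(=O)Nc2nn[nH]n2)nc(-c2ccccc2)c1` gives 50% in this assay, the lowest of the three numbers; it sits within the scatter of compound 2 but well below compound 1.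

Compound 4 `COc1ccc(-c2cc(C)cc(C(=O)Nc3nn[nH]n3)n2)cc1` has not yet been measured. Relative to compound 3 the change is methoxy in place of hydrogen on an aromatic carbon, on a six-membered aromatic ring of carbon only, para to a large group. Going by the values given here, the only single-point step recorded is a number 40 percentage points lower from compound 1 to compound 2 (beyond the scatter), a change on a different ring that does not bear on adding a methoxy to the phenyl ring. Among the compounds with values here, no measured pair isolates the present change, so there is no direct precedent to set its size.

In the absence of a bearing step, a change of roughly a number 5 percentage points higher from compound 3 to compound 4 (within the scatter) is expected, within the scatter. Compound 4 is therefore estimated at 55%, in a range from 30% to 80%.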

Compound 4, a percentage reported as inhibition, in the whole organism at one dose (the size of the read-out at that dose, not a potency): 43%
Beside the measured number, compound 4's estimate is 12 percentage points above it; the range from low to high includes it.
By their numbers in this assay, from the lowest: compounds 4, 3 and 2 (each within the scatter of the next, the first and the last beyond it); then compound 1.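

In this assay, methoxy in place of hydrogen on the six-membered aromatic ring of carbon only, para to a large group, gives a number 7 percentage points lower from compound 3 to compound 4 (within the scatter) and so, with methyl on the other ring, hydrogen and methoxy cannot be told apart at this place. With that methoxy held constant, the other ring's substituent now reads as a series of three: methyl in place of methoxy gives a number 17 percentage points lower from compound 2 to compound 4 (beyond the scatter) and methyl in place of chloro gives a number 57 percentage points lower from compound 1 to compound 4 (beyond the scatter), so chloro stands clearly apart from both. No available evidence accounts for these differences.

From the compounds shown here alone, whether the methoxy step would hold with chloro rather than methyl on the other ring remains open. So does what a hydroxyl group or an amine would do at the same place on the carbon-only ring.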